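Aminophenyl to Dichlorophenyl: an Expected Shift in Cytotoxicity

The compounds below may be only part of what the source reports. "The series", "measured", "known", "first", "only" and "open" are said of these compounds alone.

Measured compounds:
compound 1, `COc1cc(-c2cc(/C=C/C(=O)c3ccc(N)cc3)[nH]n2)cc(OC)c1OC`: -15%
compound 2, `COc1ccc(-c2cc(/C=C/C(=O)c3ccc(OC)c(OC)c3)[nH]n2)cc1`: -23%

Of the compounds shown here, two sharing the same core have been tested in a functional assay on A549 cells (Homo sapiens) for cytotoxicity, read by sulforhodamine B assay, with a stated time of 48 h, tested at 10 uM; a higher number here means a weaker effect of the compound at the concentration tested, a lower number a stronger effect. Compound 1 gives -15%, and compound 2 gives -23%. Compound 1 has the higher of the two numbers, but the gap to compound 2 is within the scatter, so the two values cannot be told apart.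

Compound 3, `COc1cc(-c2cc(/C=C/C(=O)c3ccc(Cl)c(Cl)c3)[nH]n2)cc(OC)c1OC`, is not yet measured. Compared with compound 1 it carries 3,4-dichlorophenyl in place of 4-aminophenyl on a carbonyl carbon. Going by the values given here, no step between measured compounds shows the effect of such a change, so any expectation rests on the change itself rather than on a measured precedent. For compound 3 a moderate step toward a stronger effect is expected, expressed as a number 15 percentage points lower from compound 1 to compound 3 (beyond the scatter), though a change no larger than the scatter would not be surprising. Compound 3 is therefore estimated at -30%, with a likely range from -60% to 5%.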

Compound 3, a percentage reported as activity, at one concentration (the size of the read-out at that concentration, not a potency): 68%
For compound 3 the middle estimate is 98 percentage points below the measured one, outside the stated range (above it).
By their numbers in this assay, from the lowest: compounds 2 and 1 (each within the scatter of the next); then compound 3.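

In this assay, putting 3,4-dichlorophenyl in place of 4-aminophenyl on a carbonyl carbon gives a number 83 percentage points higher from compound 1 to compound 3 (beyond the scatter), a large step toward a weaker effect. Compounds 1 and 2 could not show this, as they differ in more than one place and their values lie within the scatter of each other. This single pair shows that the group on this carbonyl carbon is not a silent passenger: with the rest of the molecule unchanged, exchanging it alone moves the read-out far beyond the scatter. No measured information on any property of these compounds accounts for the size of this step.

The pair also cannot separate the loss of the amino group from the arrival of the two chlorine atoms, since both happen in one change. A plain phenyl or a 4-chlorophenyl group on the same carbonyl carbon, with the rest of compound 1 kept, would show whether the weaker effect follows the missing amine, the added chlorines or both together.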